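The compounds below may be only part of what the source reports. "The series", "measured", "known", "first", "only" and "open" are said of these compounds alone.

The measured compounds:

Compound 1, `N[C@H]1CC[C@H](Nc2c(C(=O)NCc3ccc(F)cc3)nc(N3CCCCC3)c3cccnc23)CC1`, in a functional assay on SK-BR-3 cells (Homo sapiens) for cytotoxicity, read by MTT assay, with a stated time of 72 h (a higher number here means a weaker inhibitor, a lower number a stronger inhibitor), gives > 10000 nM.
Compound 2, `N[C@H]1CC[C@H](Nc2c(C(=O)NCc3ccc(Oc4ccccc4)cc3)nc(Br)c3cccnc23)CC1`, has no result reported in this assay: "not determined" (no result reported).
Compound 3, `N[C@H]1CC[C@H](Nc2c(C(=O)NCc3ccccn3)nc(Br)c3cccnc23)CC1`, likewise has no result in this assay: "not determined" (no result reported).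

For compound 1 the value is a limit of the assay, not a number, (the limit of > 10000 nM in this assay, at which 1 of the 3 values shown sits). Compound 3 therefore stands on no single number of its own; of the three entries shown, one is a limit and one is an entry without a number, so nothing measured describes where compound 3 lies.

Compound 4, `N[C@H]1CC[C@H](Nc2c(C(=O)NCc3ccc(Cl)cc3Cl)nc(Br)c3cccnc23)CC1`, differs from compound 3 in one place: 2,4-dichlorophenyl in place of pyridin-2-yl on a saturated chain carbon bound to an amide-type nitrogen. Going by the values given here, no measured pair connects these two compounds, and the only reported value in the set is a limit; the size of the step from compound 3 to compound 4 in this assay cannot be taken from the data. The expectation is a step of no more than the usual scatter in either direction, with the chance that the result is again a limit.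

Compound 4 is expected to give about 6000 nM in this assay, estimated to lie between 1500 nM and 30000 nM.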

Compound 4, half-maximal inhibitory concentration: 6000 nM
The estimate for compound 4 equals the measured number at the digits printed, within the range that was stated.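

Going by these compounds alone, compound 3 has no number in this assay, while compound 4 gives 6000 nM, so no step between the two can be read. The compounds shown leave open how replacing pyridin-2-yl with 2,4-dichlorophenyl, or any other single change on the shared core, shifts the result in this assay.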